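This account rests on a few compounds, and the source may have more. Where it says the series, first, only, none or still open, it means among the compounds named here.

Measured compounds:
Compound 1 `CCC1(C)C(=O)N(c2ccccc2)c2ncccc21`; in a functional assay on the whole organism (Pleural cavity) for inhibition, with Rattus norvegicus as the target, at a dose of 25 mg/kg (a lower number here means less inhibition, a higher number more inhibition at the dose given (going by the name of the read-out)), compound 1 gives 36%.
Compound 2 `CCCCC1(C)C(=O)N(c2ccccc2)c2ncccc21`; in this assay compound 2 gives 21%.

Going by the values given here, compound 2 stands lowest of the two numbers; its nearest neighbour is compound 1, higher by the one measured step. That step, a number 15 percentage points lower from compound 1 to compound 2 (beyond the scatter), is the only one available, and it ran from ethyl to butyl on the saturated chain carbon.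

Compound 3 `CC1C(=O)N(c2ccccc2)c2ncccc21` differs from compound 2 by hydrogen in place of butyl on a saturated ring carbon. The change is not the reverse of the measured step: the whole butyl chain is removed from a saturated ring carbon rather than shortened along a chain. The measured step suggests that a smaller group at this position goes with more inhibition, so a rise is expected, though with little support. The estimated step is a number 17 percentage points higher from compound 2 to compound 3 (beyond the scatter). Compound 3 is therefore expected to give about 38%, between 18% and 58%.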

Compound 3, a percentage reported as inhibition, in the whole organism at one dose (the size of the read-out at that dose, not a potency): 29%
The estimate for compound 3 lay 9 percentage points above the measured number, and the stated range covers the measured number.
By their numbers in this assay, from the lowest: compounds 2, 3 and 1 (each within the scatter of the next, the first and the last beyond it).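

In this assay, neither step to hydrogen on this saturated ring carbon clears the scatter: hydrogen in place of butyl gives a number 8 percentage points higher from compound 2 to compound 3 (within the scatter), and hydrogen in place of ethyl gives a number 7 percentage points lower from compound 1 to compound 3 (within the scatter). Compound 3 thus cannot be told apart from compound 2 or from compound 1, although those two differ beyond the scatter. The earlier pair could suggest that a shorter chain here goes with more inhibition, but with hydrogen in the series, a steady rise as the chain shortens is not established.

From the compounds shown here alone, it remains open whether an amine or a carboxylic acid on this saturated ring carbon would shift the number beyond the scatter in this assay. Going by these compounds, it is also open how a chain longer than butyl would read. No available evidence bears on this result.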